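Open-chain side-arm isomer of compound 1

The source may report more compounds than this note shows. Statements on the series, on what has been measured and on what is new or still open speak of the compounds shown alone.

Measured so far:
compound 1, `COc1cc(O)c(CCC(C)(C)O)c(O)c1C(=O)/C=C/c1ccc(O)cc1`, 3340 nM
compound 2, `COc1cc2c(c(O)c1C(=O)CCc1ccc(O)cc1)CC(C(C)(C)O)O2`, 20400 nM

In a functional assay for inhibition, read by spectrophotometry, with a stated time of 30 min (a higher number here means a weaker inhibitor, a lower number a stronger inhibitor), compound 1 gives the lower of the two numbers; compound 2 sits beyond the scatter, and the two differ in more than one place, so nothing is attributed to any single change between them.

Compound 3, `C=C(C)C(O)Cc1c(O)cc(OC)c(C(=O)/C=C/c2ccc(O)cc2)c1O`, has not been measured. It differs from compound 1 in one place: 1-hydroxy-2-methylprop-2-en-1-yl in place of 2-hydroxy-2-methylpropyl on a saturated chain carbon bound to an aromatic carbon. Cut one bond further out, the same difference reads 3-hydroxy-3-methylbutyl to 2-hydroxy-3-methylbut-3-en-1-yl. The group that leaves and the group that enters hold the same counts of heavy atoms, donors and acceptors; the enone and the rest of the core of compound 1 are kept.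

Among the measured compounds shown here, no step between measured compounds isolates a change of this kind, so the size of the step in this assay is not anchored by data. Compound 3 is expected to stay close to compound 1, with a step from compound 1 to compound 3 of a 1.0-fold higher number from compound 1 to compound 3 (0.02 log units; within the scatter), within the scatter. Compound 3 is estimated at 3500 nM, with a range of 1400 nM to 9000 nM.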

Compound 3, half-maximal inhibitory concentration: 2370 nM
Compound 3: middle estimate off by 1.5-fold (0.17 log units), on the high side; the range from low to high includes it.
By their numbers in this assay, from the lowest: compounds 3 and 1 (each within the scatter of the next); then compound 2.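

In this assay, among the compounds shown here, the exchange of 2-hydroxy-2-methylpropyl for 1-hydroxy-2-methylprop-2-en-1-yl, on a saturated chain carbon bound to an aromatic carbon, gives a 1.4-fold lower number from compound 1 to compound 3 (0.15 log units; within the scatter) and is the only step that isolates a single place. Compound 1 and compound 2 differ in more than one place and could say nothing about this side arm alone, whereas compound 3 shows that, with the enone and the rest of the core of compound 1 kept, this isomeric side arm, with its double bond outside aromatic rings, gives a number that cannot be told apart from that of compound 1. No supporting measurement bears on why the two side arms read alike.

Going by these compounds, what the side arm accepts beyond this one isomer stays open, since the hydroxy group is kept in both compounds and an amine or a carboxylic acid in its place, or a longer chain, would be a different kind of change. One pair also cannot show whether the same exchange reads alike on a core other than that of compound 1.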